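This account rests on a few compounds, and the source may have more. Where it says the series, first, only, none or still open, it means among the compounds named here.

Measured compounds:
compound 1 `CCCCCCCCC#Cc1cn(C/C=C\CN2C(=O)c3ccccc3C2=O)c(=O)[nH]c1=O` — 64000 nM
compound 2 `CCCCC#Cc1cn(C/C=C\CN2C(=O)c3ccccc3C2=O)c(=O)[nH]c1=O` — 45000 nM
compound 3 `CCCCCCC#Cc1cn(C/C=C/CN2C(=O)c3ccccc3C2=O)c(=O)[nH]c1=O` — 24000 nM

In a functional assay on MCF7 cells (Homo sapiens) for antiproliferative activity, read by MTT assay, with a stated time of 3 days (on this read-out lower numbers stand for stronger inhibition and higher numbers for weaker inhibition), compound 2 stands second highest of the three numbers, with compound 1 nearest and compound 3 furthest, both within the scatter of it. Compound 4 `O=C1c2ccccc2C(=O)N1C/C=C\Cn1cc(C#Cc2ccc(Br)cc2)c(=O)[nH]c1=O` differs from compound 2 by 4-bromophenyl in place of butyl on a triple-bonded carbon. Among the measured compounds shown here, the only measured step, a 1.4-fold lower number from compound 1 to compound 2 (0.15 log units; within the scatter), shortens the chain at the same triple bond and stays within the scatter, and no measured pair swaps the chain for an aromatic ring, so it bears only loosely on this change. The step to compound 4 is expected to be small, a 1.5-fold lower number from compound 2 to compound 4 (0.18 log units; within the scatter), with the direction uncertain. Compound 4 is estimated at 30000 nM, within 8000 nM to 120000 nM.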

Compound 4, half-maximal inhibitory concentration: > 100000 nM
Compound 4: no number, only a limit; the forecaster's own chance of this, stated with the estimate: 20%; at least 3.3-fold (0.52 log units) between middle value and limit.
By their numbers in this assay, from the lowest: compounds 3, 2 and 1 (each within the scatter of the next, the first and the last beyond it). At a limit, above all of these: compound 4.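

In this assay, compound 4 gives only a limit, not a number: the limit of > 100000 nM in this assay, at which 1 of the 4 values shown sits.

At the triple-bonded carbon, 4-bromophenyl in place of butyl gives an at least 2.2-fold higher number from compound 2 to compound 4 (0.34 log units; beyond the scatter), so an aromatic ring here moves the read-out toward weaker inhibition, which the chain change alone did not show. Against octyl the same swap gives an at least 1.5-fold higher number from compound 1 to compound 4 (0.19 log units; that floor lies within the scatter), and that pair alone fixes no order.

Going by these compounds, the true size of both steps stays open, as only a floor is known. Also open, on these data alone, is whether plain phenyl, or a phenyl carrying an amine or a carboxylic acid, would read like 4-bromophenyl.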